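Naphthylmethyl replacement on the benzylsulfanyl arm

A few compounds are considered here, and "the series" means these few. Any claim that something is new, unique, unknown or untested is made for them only; others in the source may bear on it.

Measured compounds:
compound 1 `Cc1cccc(CSc2cc(Cl)c(C)cc2S(=O)(=O)/N=C(\N)n2nccc2-c2ccccc2)c1` — 47000 nM
compound 2 `Cc1cccc(CSc2cc(Cl)c(C)cc2S(=O)(=O)/N=C(\N)n2nc(C)cc2-c2ccccc2)c1` — 105000 nM
compound 3 `Cc1cc(-c2ccccc2)n(/C(N)=N/S(=O)(=O)c2cc(C)c(Cl)cc2SCc2ccccc2)n1` — 15000 nM

In a functional assay on MCF7 cells (Homo sapiens) for cytotoxicity, read by MTT assay, with a stated time of 72 h (a higher number here means a weaker inhibitor, a lower number a stronger inhibitor), compound 1 sits second highest of the three values shown, with compound 2 above it and compound 3 below it. Compound 4 `Cc1cc(S(=O)(=O)/N=C(\N)n2nccc2-c2ccccc2)c(SCc2cccc3ccccc23)cc1Cl` differs from compound 1 only on the sulfanyl arm: naphthalen-1-yl in place of 3-methylphenyl on a saturated chain carbon bound to a sulfur.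

Neither measured step touches that arm. The step of a 2.2-fold higher number from compound 1 to compound 2 (0.35 log units; beyond the scatter) and the step of a 7.0-fold lower number from compound 2 to compound 3 (0.85 log units; beyond the scatter) both concern a methyl on an aromatic carbon of the shared core, and both were modest. For the measured compounds named here, nothing among the measured compounds shows what a change on the benzyl group does, so the expectation for compound 4 is a step no larger than those, in no firm direction.

Compound 4 is therefore estimated at 40000 nM in this assay, between 12000 nM and 130000 nM, an expected step of a 1.2-fold lower number from compound 1 to compound 4 (0.07 log units; within the scatter).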

Compound 4, half-maximal inhibitory concentration: 58000 nM
The estimate for compound 4 lay 1.5-fold (0.16 log units) below the measured number, within the range that was stated.
By their numbers in this assay, from the lowest: compound 3; then compounds 1, 4 and 2 (each within the scatter of the next, the first and the last beyond it).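

The sulfanyl arm now has its first reading: in this assay, the step of a 1.2-fold higher number from compound 1 to compound 4 (0.09 log units; within the scatter) stays within the scatter. On this saturated chain carbon bound to a sulfur, naphthalen-1-yl, with its second six-membered aromatic ring of carbon only, therefore gives a number not separable from that of 3-methylphenyl. No measurement at hand explains this result. Still open, going by these compounds, is whether an arm ending in an amine or a carboxylic acid would step beyond the scatter. Also open, on these data alone, is whether naphthalen-1-yl gives the same reading on the methyl-bearing core of compound 2.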